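The source may hold more compounds than are shown below. What is called first, only, known or untested is meant among the compounds shown, and "the series" means these compounds.

Compound 1, `O=C(NOCc1ccccc1)c1cn(-c2ccccc2)nc1-c1ccccc1`: 8830 nM
Compound 2, `O=C(NOCc1ccccc1)c1cn(-c2ccccc2)nc1-c1ccc(Cl)cc1`: 8350 nM

Both compounds were tested in a functional assay on HeLa cells (Homo sapiens) for antiproliferative activity, read by MTT assay, with a stated time of 48 h, in the presence of a further agent that is not named here; on this read-out lower numbers stand for stronger inhibition of growth and higher numbers for weaker inhibition of growth. Compound 2 and compound 1 sit within the scatter of each other there, as the step of a 1.1-fold lower number from compound 1 to compound 2 (0.02 log units; within the scatter) shows, so neither can be called more potent than the other.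

Compound 3, `O=C(NOCc1ccccc1)c1cn(-c2ccccc2)nc1-c1ccc(F)cc1`, has not yet been measured. It differs from compound 2 by fluoro in place of chloro on an aromatic carbon. Among the measured compounds shown here, the only measured step that bears on this place is the one from hydrogen to chloro, a 1.1-fold lower number from compound 1 to compound 2 (0.02 log units; within the scatter), which stayed within the scatter. Exchanging one halogen for another at a spot where adding a halogen changed nothing measurable gives no reason to expect a step beyond the scatter in this assay, in either direction. The expected step from compound 2 is therefore a 1.0-fold higher number from compound 2 to compound 3 (0.01 log units; within the scatter). For compound 3 the estimate is 8500 nM, with a range from 4000 nM to 18000 nM.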

Compound 3, concentration for 50% growth inhibition: 6110 nM
Beside the measured number, compound 3's estimate is 1.4-fold (0.14 log units) above it, and the stated range covers the measured number.
By their numbers in this assay, from the lowest: compounds 3, 2 and 1 (each within the scatter of the next).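

In this assay fluoro in place of chloro gives a 1.4-fold lower number from compound 2 to compound 3 (0.14 log units; within the scatter) and fluoro in place of hydrogen gives a 1.4-fold lower number from compound 1 to compound 3 (0.16 log units; within the scatter) on the same aromatic carbon. A second halogen has now been read at this position, and hydrogen, chloro and fluoro all lie within the scatter of one another, so no order can be drawn among the three. Among the compounds shown here, the earlier pair showed only that chloro left the number unreadably changed, whereas these steps show the same for fluoro, and the 4-chlorophenyl to 4-fluorophenyl exchange also produces no step beyond the scatter.

From the compounds shown here alone, whether a larger or very different group at this position, such as an amine, a carboxylic acid or a longer chain, would move the number remains open. Nothing here gives a measured reason for these numbers.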